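This account rests on a few compounds, and the source may have more. Where it says the series, first, only, none or still open, it means among the compounds named here.

Measured so far in a functional assay on PANC-1 cells (Homo sapiens) for inhibition, read by MTT assay, with a stated time of 24 h, tested at 10 uM; on this read-out higher numbers stand for more inhibition at the one concentration tested (going by the name of the read-out) and lower numbers for less inhibition:
compound 1 `CC(C)=CCC1Cc2c(O)cc(=O)n(CCCO)c2CC1(C)C` gives 25.6%
compound 2 `COc1ccc(C(=O)NCCCOc2cc(=O)n(CCCO)c3c2CC(CC=C(C)C)C(C)(C)C3)cc1` gives 55.5%
compound 3 `CC(C)=CCC1Cc2c(OCCCNC(=O)c3ccc([N+](=O)[O-])cc3)cc(=O)n(CCCO)c2CC1(C)C` gives 49.9%

Compound 3 stands second of the three numbers; its gap to compound 2 is within the scatter, its gap to compound 1 beyond it. Compound 4 `CC(C)=CCC1Cc2c(OCCCOc3ccc(Cl)cc3)cc(=O)n(CCCO)c2CC1(C)C` is not yet measured. Change from compound 3 to compound 4: 4-chlorophenoxy in place of ((4-nitrophenyl)carbonyl)amino on a saturated chain carbon, three bonds along the chain from an oxygen on an aromatic ring.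

For the measured compounds named here, the one measured step touching this end of the molecule is a number 5.6 percentage points lower from compound 2 to compound 3 (within the scatter), an exchange of one substituent on an aromatic carbon that left the read-out within the scatter. Going by the values given here, the present change is larger, swapping a ((4-nitrophenyl)carbonyl)amino group for a 4-chlorophenoxy group, and no measured pair shows such an exchange. Among the compounds with values here, the only further pointer is compound 1, which carries neither group and gives 25.6%, clearly lower than compound 2 and compound 3. A step within the scatter, in either direction, is therefore the expectation. In this assay compound 4 is expected to give 45%, between 27% and 63%. That estimate means an expected step of a number 4.9 percentage points lower from compound 3 to compound 4 (within the scatter).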

Compound 4, a percentage reported as inhibition, at one concentration (the size of the read-out at that concentration, not a potency): 22.7%
Beside the measured number, compound 4's estimate is 22.3 percentage points above it, outside the stated range (below it).
By their numbers in this assay, from the lowest: compounds 4 and 1 (each within the scatter of the next); then compounds 3 and 2 (each within the scatter of the next).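

In this assay this chain end proves sensitive to the group it carries: replacing ((4-nitrophenyl)carbonyl)amino with 4-chlorophenoxy gives a number 27.2 percentage points lower from compound 3 to compound 4 (beyond the scatter) and replacing ((4-methoxyphenyl)carbonyl)amino with it gives a number 32.8 percentage points lower from compound 2 to compound 4 (beyond the scatter), whereas the earlier exchange on the aromatic carbon stayed within the scatter. Adding 3-(4-chlorophenoxy)propyl in place of hydrogen on the oxygen gives a number 2.9 percentage points lower from compound 1 to compound 4 (within the scatter), so compound 4 goes against any reading that substitution on this oxygen alone accompanies the higher numbers of compound 2 and compound 3. Nothing available explains the difference between these chain ends.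

Both exchanges change the link to the chain and the substituent on the benzene ring together, so their separate contributions remain unresolved. A ((4-chlorophenyl)carbonyl)amino group would separate the two, and a simple amine or carboxylic acid at the chain end would show whether an aromatic ring is needed there at all.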